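Swapping the amide aryl group: from compound 1 to compound 4

The source may hold more compounds than are shown below. What is called first, only, known or untested is meant among the compounds shown, and "the series" means these compounds.

The compounds share one core, seen in compound 1 `Cc1cccc(Cl)c1NC(=O)CN1CCN(c2nnc(Cc3ccncc3)c3ccccc23)CC1`, which carries a substituted phenyl group on an amide-type nitrogen. Among the measured compounds shown here, in a functional assay on MDA-MB-231 cells (Homo sapiens) for cytotoxicity, read by MTT assay, with a stated time of 72 h (on this read-out lower numbers stand for stronger inhibition and higher numbers for weaker inhibition), compound 1 gives 2670 nM, the lowest of the three numbers measured so far. Compound 3 `O=C(CN1CCN(c2nnc(Cc3ccccc3)c3ccccc23)CC1)Nc1cccc(Br)c1` gives 3880 nM, which sits within the scatter of compound 1. Compound 2 `O=C(CN1CCN(c2nnc(Cc3ccccc3)c3ccccc23)CC1)Nc1ccc(Br)cc1` gives 12400 nM, well beyond the scatter of compound 1.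

For the measured compounds named here, only one measured step is a one-place change: a 3.2-fold lower number from compound 2 to compound 3 (0.50 log units; beyond the scatter). It shows that moving a single substituent around the phenyl group on the amide nitrogen can shift the number by more than the scatter.

Compound 4 `O=C(CN1CCN(c2nnc(Cc3ccncc3)c3ccccc23)CC1)Nc1ccc(F)c(C(F)(F)F)c1` differs from compound 1 in exactly that region: 4-fluoro-3-(trifluoromethyl)phenyl in place of 2-chloro-6-methylphenyl on an amide-type nitrogen. Here both substituents leave their places and two new ones arrive elsewhere, so the one measured step offers only a hint, not a direct guide. A step beyond the scatter in either direction is possible, and on this evidence a mild weakening is expected, a 1.5-fold higher number from compound 1 to compound 4 (0.18 log units; within the scatter). Compound 4 is therefore estimated at 4000 nM, with a range from 1500 nM to 12000 nM.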

Compound 4, half-maximal inhibitory concentration: 1.9 nM
Beside the measured number, compound 4's estimate is 2100-fold (3.32 log units) above it, and the stated range ends above it.
By their numbers in this assay, from the lowest: compound 4; then compounds 1 and 3 (each within the scatter of the next); then compound 2.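

In this assay, among the compounds shown here, exchanging one aryl group for the other on the amide-type nitrogen gives a 1400-fold lower number from compound 1 to compound 4 (3.15 log units; beyond the scatter) and dwarfs the only earlier step of this kind, a 3.2-fold lower number from compound 2 to compound 3 (0.50 log units; beyond the scatter) as the bromine changes place, so this position can move the number over a far wider span than compounds 2 and 3 alone could show. The change is also a bundle: 2-chloro-6-methylphenyl leaves whole and 4-fluoro-3-(trifluoromethyl)phenyl enters whole, so the large step belongs to the pair of groups and cannot be divided among the chlorine, the methyl, the fluorine and the trifluoromethyl. No measurement at hand accounts for the size of this step.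

Going by these compounds, it remains open whether a phenyl group carrying only the fluorine or only the trifluoromethyl would keep much of this gain, and whether an amine or a carboxylic acid on that phenyl group would be tolerated. On these data alone, it is also open whether the same aryl group would give a similar step on the core of compound 3, where the rest of the molecule differs from that of compound 4.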